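Solubility of compound 3 after an acyl change

The source may report more compounds than this note shows. Statements on the series, on what has been measured and on what is new or still open speak of the compounds shown alone.

Measured in a physicochemical assay for solubility, with a stated time of 24 h, tested at 30 mg/mL; on this read-out higher numbers stand for higher solubility and lower numbers for lower solubility:
- compound 1 `CC(=O)N1CC(CC(=O)NO)(NS(=O)(=O)c2ccc(OCc3cc(C)nc4ccccc34)cc2)C1`: 800000 nM
- compound 2 `CC(=O)N1CC(CC(=O)NO)(NS(=O)(=O)c2ccc(OCc3cc(C)nc4ccccc34)c(C)c2)C1`: 400000 nM

Within the data shown here, compound 1, at 800000 nM, stands within the scatter of compound 2, the only other number. Compound 3 `Cc1cc(COc2ccc(S(=O)(=O)NC3(CC(=O)NO)CN(C(=O)C(C)(C)N(C)C)C3)cc2)c2ccccc2n1` differs from compound 1 thus: 1-(dimethylamino)-1-methylethyl in place of methyl on a carbonyl carbon. Among the measured compounds shown here, the sole measured step, a 2.0-fold lower number from compound 1 to compound 2 (0.30 log units; within the scatter), is a different change, methyl in place of hydrogen on an aromatic carbon, so it bears only weakly. For the measured compounds named here, no measured step covers the new change, and the expectation in this assay, resting on the structural change alone, is a loose one toward a higher number. The expected step is a 10-fold higher number from compound 1 to compound 3 (1.00 log units; beyond the scatter). Compound 3 is estimated at 8000000 nM, with an expected range from 1000000 nM to 50000000 nM.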

Compound 3, solubility: 11000000 nM
Beside the measured number, compound 3's estimate is 1.4-fold (0.14 log units) below it; the measured number falls inside the stated range.
By their numbers in this assay, from the lowest: compounds 2 and 1 (each within the scatter of the next); then compound 3.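

In this assay, among these compounds, 1-(dimethylamino)-1-methylethyl in place of methyl on the carbonyl carbon gives a 14-fold higher number from compound 1 to compound 3 (1.14 log units; beyond the scatter), a step beyond the scatter, whereas the only earlier step, at an aromatic carbon, stayed within it. This carbonyl position therefore carries a large change in this read-out, and the change runs toward a higher number. Nothing measured here explains the rise.

The compounds shown leave open whether the dimethylamino nitrogen or the added carbons account for the step. A tert-butyl or a carboxylic acid chain on the same carbonyl carbon would separate the two.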